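Series notes: compound 2 to compound 3 in the reporter assay

The source may hold more compounds than are shown below. What is called first, only, known or untested is meant among the compounds shown, and "the series" means these compounds.

Compound 2 `COc1ccc(Cl)c(-c2noc(C(C)C)c2COc2ccc(-c3ccc4c(C(=O)O)cn(C)c4c3)c(C)c2)n1` gives 2000 nM in a functional assay for agonist activity at Bile acid receptor (Homo sapiens), read by a luciferase reporter (on this read-out lower numbers stand for an effect already at smaller amounts and higher numbers for an effect only at larger amounts of compound), the lowest of the two numbers seen so far; compound 1 `Cc1cc(OCc2c(-c3cc[nH]c(=O)c3Cl)noc2C(C)C)ccc1-c1ccc2c(C(=O)O)cn(C)c2c1` gives 5000 nM. Compound 3 `Cc1cc(OCc2c(-c3ccn(C)c(=O)c3Cl)noc2C(C)C)ccc1-c1ccc2c(C(=O)O)cn(C)c2c1` differs from compound 2 by a group of 9 heavy atoms (6 carbon, 1 nitrogen, 1 oxygen, 1 chlorine; one six-membered aromatic ring with 1 hetero atom) in place of a group of 9 heavy atoms (6 carbon, 1 nitrogen, 1 oxygen, 1 chlorine; one six-membered aromatic ring with 1 hetero atom), on an aromatic carbon. Among the compounds with values here, the only measured step bearing on this position is a 2.5-fold lower number from compound 1 to compound 2 (0.40 log units; beyond the scatter), and since the group entering compound 3 is the same set of atoms as in compound 2 joined differently, that step is only a loose guide. A modest change in either direction is therefore expected, and the estimate for compound 3 is placed between the two measured values, a step of a 1.8-fold higher number from compound 2 to compound 3 (0.24 log units; within the scatter). Compound 3 is estimated at 3500 nM, range 1500 nM to 9000 nM.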

Compound 3, half-maximal effective concentration: 7000 nM
Estimate against measurement, compound 3: 2.0-fold (0.30 log units) below; low and high end bracket the measured number.
By their numbers in this assay, from the lowest: compound 2; then compounds 1 and 3 (each within the scatter of the next).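

In this assay, replacing the 3-chloro-6-methoxypyridin-2-yl group with a group of the same atoms joined differently gives a 3.5-fold higher number from compound 2 to compound 3 (0.54 log units; beyond the scatter), so at this position the arrangement of the atoms matters, not only their identity. Methyl in place of hydrogen on the aromatic nitrogen gives a 1.4-fold higher number from compound 1 to compound 3 (0.15 log units; within the scatter), which leaves compound 1 and compound 3 within the scatter of each other. No measurement at hand accounts for either step. Still open, as far as these compounds go, is whether an ethoxy group or an amine in place of the methoxy of compound 2 would lower the number. A longer chain on the aromatic nitrogen of compound 3 also remains an open case.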